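This account rests on a few compounds, and the source may have more. Where it says the series, first, only, none or still open, it means among the compounds named here.

In a functional assay on SEM cells (Homo sapiens) for cytotoxicity, with a stated time of 72 h (a lower number here means that less compound is needed, a higher number that more compound is needed for the effect), compound 1 (`COc1ccc(/C=C/[C@@](C)(/C=C/c2ccc(O)c(/C=C/C(=O)OC(C)(C)C)c2)CCC=C(C)C)cc1`) gives > 36600 nM as a limit of the assay, not a number. Compound 2 (`COc1ccc(/C=C/[C@@](C)(/C=C/c2ccc(O)cc2)CCC=C(C)C)cc1`) likewise gives > 36600 nM and this too is only a limit. From the compounds shown here alone, compound 2 therefore stands at the limit of > 36600 nM in this assay, at which 2 of the 2 values shown sit, and its true position is unknown.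

Compound 3 (`CCOc1ccc(/C=C/[C@@](C)(/C=C/c2ccc(O)cc2)CCC=C(C)C)cc1`) differs from compound 2 in a single place: methyl in place of hydrogen on a saturated chain carbon bound to an oxygen on an aromatic ring. The methoxy group becomes ethoxy, so 4-methoxyphenyl turns into 4-ethoxyphenyl.

Among the measured compounds shown here, only one measured step is available, and it lies elsewhere on the molecule, where hydrogen replaces 2-(tert-butoxycarbonyl)ethenyl. That step is a step that the two limits leave unreadable from compound 1 to compound 2 and so it gives no size to carry over. For the measured compounds named here, no measured step touches the methoxy group itself.

With so little to go on, the most reasonable expectation in this assay is no real change. The expected step is a step that the limit leaves unreadable from compound 2 to compound 3 and no direction beyond the scatter is foreseen. Most likely the assay will again report only a limit. For compound 3 the estimate is 40000 nM with an expected range from 20000 nM to 80000 nM as its ends.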

Compound 3, half-maximal effective concentration: > 36600 nM
Compound 3: a limit, no number; the forecaster's own chance of this, stated with the estimate: 85%; the middle value does not contradict the limit.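

In this assay compound 3 gives > 36600 nM, again a limit and not a number, so the steps linking compound 1, compound 2 and compound 3 cannot be read. The compounds shown leave open where each truly stands in this assay, and whether going from methoxy to ethoxy has any effect there.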